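The compounds below may be only part of what the source reports. "The series", "measured", "known", "first", "only" and "open" are said of these compounds alone.

In a functional assay on MCF7 cells (Homo sapiens) for cytotoxicity, read by sulforhodamine B assay, with a stated time of 48 h (a lower number here means a stronger inhibitor, a higher number a weaker inhibitor), compound 1 `C=CCOc1ccc(F)cc1C(=O)c1cccnc1` gives only a limit, > 100000 nM; this is the limit of > 100000 nM in this assay, at which 1 of the 3 values shown sits. Compound 2 `O=C(c1cccnc1)c1cc(F)ccc1O` gives 27800 nM in this assay. The change between the two is hydrogen in place of allyl on an oxygen on an aromatic ring, and it made a step of an at least 3.5-fold lower number from compound 1 to compound 2 (0.55 log units; beyond the scatter). Compound 3 `C=CCOc1ccc(C)cc1C(=O)c1cccnc1` gives 84000 nM in this assay; it differs from compound 1 by methyl in place of fluoro on an aromatic carbon, a step of an at least 1.1-fold lower number from compound 1 to compound 3 (0.07 log units; that floor lies within the scatter), which is how the two cores differ. Compound 4 `Cc1ccc(O)c(C(=O)c2cccnc2)c1` has not yet been measured. It differs from compound 3 by hydrogen in place of allyl on an oxygen on an aromatic ring, the same change as from compound 1 to compound 2, made at the same place, on a core that carries methyl where the core of compound 1 carries fluoro. Because the step of an at least 3.5-fold lower number from compound 1 to compound 2 (0.55 log units; beyond the scatter) rests on a limit for compound 1, only its floor is known, not its full size. Starting from compound 3, a step of a 3.5-fold lower number from compound 3 to compound 4 (0.54 log units; beyond the scatter) is expected, resting on that floor. Compound 4 is therefore estimated to give 24000 nM in this assay, expected to lie between 8000 nM and 70000 nM.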

Compound 4, half-maximal inhibitory concentration: 8040 nM
Compound 4: the middle estimate sits 3.0-fold (0.47 log units) above what was measured; the measured number falls inside the stated range.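

In this assay, putting hydrogen in place of allyl on the oxygen gives a 10-fold lower number from compound 3 to compound 4 (1.02 log units; beyond the scatter), so on the core with methyl the size of the change is fully known, and it points the same way as on the core with fluoro: the same change on two cores in this assay, an at least 3.5-fold lower number (0.55 log units; beyond the scatter) from compound 1 to compound 2 and a 10-fold lower number (1.02 log units; beyond the scatter) from compound 3 to compound 4; the limit leaves it open whether they differ. Compound 1 gives only a limit, so the step on the core with fluoro is a floor, and the data do not show whether the change is equal in size on the two cores. Methyl in place of fluoro, seen in the pair with a free hydroxy, gives a 3.5-fold lower number from compound 2 to compound 4 (0.54 log units; beyond the scatter), and its comparison with the allyloxy pair stays open in the same way: the same change on two cores in this assay, an at least 1.1-fold lower number (0.07 log units; that floor lies within the scatter) from compound 1 to compound 3 and a 3.5-fold lower number (0.54 log units; beyond the scatter) from compound 2 to compound 4; the limit leaves it open whether they differ.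

With only two cores shown, it remains open whether the change would carry over to a core with chloro or methoxy in place of methyl or fluoro. From the compounds shown here alone, it is also open how an oxygen carrying a longer chain, or a chain ending in an amine or a carboxylic acid, would compare with allyl and hydrogen.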